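The source may hold more compounds than are shown below. What is called first, only, known or untested is meant among the compounds shown, and "the series" means these compounds.

Measured in an ADME assay on NIH3T3 cells (Mus musculus) for cytotoxicity, read by MTT assay, with a stated time of 24 h; on this read-out higher numbers stand for weaker inhibition and lower numbers for stronger inhibition:
compound 1 `O=C(CSc1nnc(COc2ccc3c(c2)CCCC3)o1)Nc1nc2ccc(F)cc2s1`: 292000 nM
compound 2 `O=C(CSc1nnc(COc2ccc3c(c2)CCCC3)o1)Nc1nc2ccc([N+](=O)[O-])cc2s1`: 336000 nM
compound 3 `O=C(CSc1nnc(COc2ccc3c(c2)CCCC3)o1)Nc1nccs1`: > 403000 nM, a limit and not a number

Within the data shown here, compound 1 stands level with the only other exact number in the set, and the remaining value is a limit. Compound 4 `O=C(CSc1nnc(COc2ccc3c(c2)CCCC3)o1)Nc1ncc([N+](=O)[O-])s1` carries 5-nitro-1,3-thiazol-2-yl in place of 6-fluoro-1,3-benzothiazol-2-yl on an amide-type nitrogen. Two measured steps each bear on part of this change. The exchange of fluoro for nitro gave a 1.2-fold higher number from compound 1 to compound 2 (0.06 log units; within the scatter), which lies within the scatter. From the compounds shown here alone, the exchange of the ring group gave an at least 1.3-fold higher number from compound 1 to compound 3 (0.13 log units; that floor lies within the scatter), and the floor of that step lies within the scatter, so its true size remains open. Neither step goes beyond the scatter, so no step beyond the scatter is expected in this assay for the combined change. The expected step is a 1.1-fold higher number from compound 1 to compound 4 (0.04 log units; within the scatter). Compound 4 is estimated at 320000 nM, with an expected range from 170000 nM to 550000 nM.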

Compound 4, half-maximal inhibitory concentration: > 403000 nM
Compound 4: only a limit was reported; the forecaster's own chance of this, stated with the estimate: 30%; middle value at least 1.2-fold (0.10 log units) away from the limit.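

In this assay compound 4 gives > 403000 nM, which is a limit and not a number. Placing 5-nitro-1,3-thiazol-2-yl in place of 6-fluoro-1,3-benzothiazol-2-yl on the amide-type nitrogen gives an at least 1.3-fold higher number from compound 1 to compound 4 (0.13 log units; that floor lies within the scatter), so this exchange, which joins a nitro group to the ring change, shows no step beyond the scatter that can be read. The step for nitro in place of hydrogen, from compound 3 to compound 4, cannot be read because both values are limits: the limit of > 403000 nM in this assay, at which 2 of the 4 values shown sit.

From the compounds shown here alone, how far compound 3 and compound 4 truly lie from compound 1 stays open, and with it the full size of the ring exchange. Also open, going by these compounds, is whether an amine or a carboxylic acid in place of the nitro group would give a step beyond the scatter.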